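Swapping a dichlorophenyl for ethoxycarbonyl in a chalcone amide

This account rests on a few compounds, and the source may have more. Where it says the series, first, only, none or still open, it means among the compounds named here.

Compound 1 `COc1cc(/C=C/C(=O)c2cccc(NC(=O)c3c(Cl)cccc3Cl)c2)ccc1O`: 3.56 ug/mL
Compound 2 `COc1cc(/C=C/C(=O)c2cccc(NC(=O)c3cc(Cl)cc(Cl)c3)c2)ccc1O`: 17.7 ug/mL
Compound 3 `COc1cc(/C=C/C(=O)c2cccc(NC(=O)c3ccc(Cl)cc3Cl)c2)ccc1O`: 34.4 ug/mL

These values come from a functional assay on SiHa cells (Homo sapiens) for inhibition; a lower number here means a stronger inhibitor, a higher number a weaker inhibitor. Compound 3 stands at the upper end of the numbers together with compound 2, with a 1.9-fold higher number from compound 2 to compound 3 (0.29 log units; within the scatter). Compound 1 lies clearly apart, with a 9.7-fold higher number from compound 1 to compound 3 (0.99 log units; beyond the scatter).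

Compound 4 `CCOC(=O)C(=O)Nc1cccc(C(=O)/C=C/c2ccc(O)c(OC)c2)c1` shares the core of compound 3 and differs in one place: ethoxycarbonyl in place of 2,4-dichlorophenyl on a carbonyl carbon. In words, this is ethoxycarbonyl in place of 2,4-dichlorophenyl on a carbonyl carbon.

Among the compounds with values here, no measured step covers an exchange of this kind. The nearest evidence is the set of moves among dichlorophenyl groups on that same carbon. These show a 5.0-fold higher number from compound 1 to compound 2 (0.70 log units; beyond the scatter) and a 9.7-fold higher number from compound 1 to compound 3 (0.99 log units; beyond the scatter), so this place can shift the number modestly. Against that, the data also show a 1.9-fold higher number from compound 2 to compound 3 (0.29 log units; within the scatter). All of these steps keep an aromatic ring, so they give no direction for its removal. A step of modest size either way remains possible, but no step beyond the scatter is the central expectation in this assay. The expected step is a 1.4-fold lower number from compound 3 to compound 4 (0.14 log units; within the scatter). For compound 4 the estimated value is 25 ug/mL, with an expected range from 7 ug/mL to 80 ug/mL.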

Compound 4, half-maximal inhibitory concentration: > 50 ug/mL
Compound 4 gave a limit, no number (the forecaster's own chance of this, stated with the estimate: 10%); at least 2.0-fold (0.30 log units) between middle value and limit.
By their numbers in this assay, from the lowest: compound 1; then compounds 2 and 3 (each within the scatter of the next). At a limit, above all of these: compound 4.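

In this assay compound 4 gives > 50 ug/mL, which is a limit and not a number: the limit of > 50 ug/mL in this assay, at which 1 of the 4 values shown sits. The earlier steps shown here all kept an aromatic ring on this carbonyl carbon, whereas ethoxycarbonyl has no ring, and this first exchange of the ring for an open group gives an at least 14-fold higher number from compound 1 to compound 4 (1.14 log units; beyond the scatter) and an at least 2.8-fold higher number from compound 2 to compound 4 (0.45 log units; beyond the scatter), so this position can move the number further than the moves among dichlorophenyl groups showed. Against the weakest-placed ring compound the reading is less firm: the floor of an at least 1.4-fold higher number from compound 3 to compound 4 (0.16 log units; that floor lies within the scatter) lies within the scatter, so the data do not separate these two, and they show only that ethoxycarbonyl brought no gain over any of the three dichlorophenyl groups.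

The compounds shown leave open how far above its limit compound 4 really lies, and whether the rise comes from losing the aromatic ring or from the ethoxycarbonyl group itself. An unsubstituted phenyl, a carboxylic acid or a longer chain such as butoxycarbonyl on this same carbonyl carbon would help to tell these apart.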